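Isopropyl to methyl on the ring amine nitrogen

The source may hold more compounds than are shown below. What is called first, only, known or untested is meant among the compounds shown, and "the series" means these compounds.

Compound 1 (`C/C(=N/c1ccnc2cc(Cl)ccc12)NC1CCN(C(C)C)CC1`) gives > 1 h (a limit)
Compound 2 (`CN(C)CCCN/C(=N\c1ccnc2cc(Cl)ccc12)c1ccccc1`) gives 0.867 h (a number)

In an ADME assay (liver, Mus musculus) for metabolic stability, read by LC-MS, using microsomes, tested at 1 uM (on this read-out lower numbers stand for a shorter-lived compound and higher numbers for a longer-lived compound), compound 1 stands at > 1 h as a limit of the assay and not a number. Compound 2 reads 0.867 h in this assay but differs from compound 1 in more than one place, so it sets no size for a single change. Going by the values given here, no pair of measured compounds differs in one place only, and the data therefore hold no direct guide to the next step.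

That step leads to compound 3 (`C/C(=N/c1ccnc2cc(Cl)ccc12)NC1CCN(C)CC1`), which has not yet been measured. The change (methyl in place of isopropyl on an amine nitrogen in a ring) is methyl in place of isopropyl on an amine nitrogen in a ring, and the rest of compound 1 stays as it is. The step of a number no higher from compound 1 to compound 3 (the limit leaves the size open) is expected to stay within the usual scatter, with neither direction favoured. In this assay the estimated value for compound 3 is 1 h with an expected range running from 0.5 h up to 1.5 h at the top.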

Compound 3, half-life: > 1 h
Compound 3 gave a limit, no number; the forecaster's own chance of this, stated with the estimate: 50%; the middle value lies on the limit itself.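

Compound 1 and compound 3 both stand at a limit of this assay and not at a number, so no step between them can be read: the limit of > 1 h in this assay, at which 2 of the 3 values shown sit.

The compounds shown leave open how long either compound actually lasts, and whether methyl in place of isopropyl on the amine nitrogen in a ring alters the half-life at all.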